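Methyl to chloro on the aryl ring of the series

This account rests on a few compounds, and the source may have more. Where it says the series, first, only, none or still open, it means among the compounds named here.

In a functional assay on PC-12 cells (Rattus norvegicus) for cytotoxicity, read by MTT assay, with stated times of 2 h and 24 h, tested at 1 uM (a lower number here means a weaker effect, a higher number a stronger effect of the compound at the concentration tested), compound 1 `Cc1ccc(-n2nc(-c3ccc(C(F)(F)F)cc3O)nc2-c2ccccc2O)cc1` gives 71.5%, the higher of the two numbers in hand; the other, compound 2 `Oc1cc(C(F)(F)F)ccc1-c1nc(-c2ccccc2O)n(-c2ccc(F)cc2)n1`, gives 67.2%. For the measured compounds named here, the only measured step, a number 4.3 percentage points lower from compound 1 to compound 2 (within the scatter), is within the scatter, so the two values read as equivalent and no order between them is claimed.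

Compound 3 `Oc1cc(C(F)(F)F)ccc1-c1nc(-c2ccccc2O)n(-c2ccc(Cl)cc2)n1` is not yet measured. Its difference from compound 1 is chloro in place of methyl on an aromatic carbon. Of the measured steps, only a number 4.3 percentage points lower from compound 1 to compound 2 (within the scatter) bears on this change: it exchanges the same methyl on the same aromatic carbon for another halogen, and it lies within the scatter. Going by the values given here, no other measured step touches that carbon, so the basis is thin, a single comparison. The expectation is therefore a step of no size beyond the scatter, a number 3.5 percentage points lower from compound 1 to compound 3 (within the scatter), with no direction asserted. For compound 3 the estimate in this assay is 68%, expected to fall between 57% and 79%.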

Compound 3, a percentage reported as activity, at one concentration (the size of the read-out at that concentration, not a potency): 68%
Compound 3: middle estimate and measured number agree at the digits printed; measured number inside the range.
By their numbers in this assay, from the lowest: compounds 2, 3 and 1 (each within the scatter of the next).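

On the aromatic carbon para to a large group, the change from 4-methylphenyl to 4-chlorophenyl gives a step in this assay (a number 3.5 percentage points lower from compound 1 to compound 3 (within the scatter)) that stays within the scatter, so a second halogen now matches the earlier reading for fluoro. For the compounds shown here, the two halogens can also be compared directly (a number 0.8 percentage points higher from compound 2 to compound 3 (within the scatter)), which turns the single comparison of the earlier pair into a set of three groups at this one place, methyl, fluoro and chloro, with no order among them. No measurement in hand accounts for this flat reading or ties it to any property of the three groups.

The compounds shown cover only methyl and two halogens at this place, so it remains open whether a different group, such as an amine, a carboxylic acid or a longer alkyl chain, would move the number beyond the scatter. On these data alone, the trifluoromethyl group and the hydroxyl groups stay the same in all three compounds, so their part in this read-out is also open.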